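Chain shortening on the aromatic substituent: cytotoxicity notes

A few compounds are considered here, and "the series" means these few. Any claim that something is new, unique, unknown or untested is made for them only; others in the source may bear on it.

Three compounds share the bicyclic amine core. Compound 1 `CCCCc1csc(CN[C@@H]2C[C@H]3C[C@@H]([C@H]2C)C3(C)C)c1` carries a butyl chain on its aromatic ring and in an ADME assay on MDCK cells (Canis lupus familiaris) for cytotoxicity, read by microscopy, with a stated time of 48 h (on this read-out higher numbers stand for lower toxicity in this test and lower numbers for higher toxicity in this test), compound 1 gives 12500 nM. Compound 2 `C[C@H]1[C@H](NCc2cncs2)C[C@H]2C[C@@H]1C2(C)C` has no alkyl chain on the aromatic ring; in this assay compound 2 reaches only the assay limit of > 100000 nM. Compound 3 `CCCc1ccsc1CN[C@@H]1C[C@H]2C[C@@H]([C@H]1C)C2(C)C` carries a propyl chain and in this assay compound 3 gives 50000 nM, the highest of the two numbers measured, with compound 1 sitting lower, a gap beyond the scatter.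

Compound 4 `CCc1ccsc1CN[C@@H]1C[C@H]2C[C@@H]([C@H]1C)C2(C)C` differs from compound 3 by hydrogen in place of methyl on a saturated chain carbon, two bonds along the chain from an aromatic carbon. For the measured compounds named here, no measured pair isolates this exact change, so the expectation rests on the values shown: the compound without a chain, compound 2, sits at the limit, the butyl compound 1 sits lowest, and the propyl compound 3 lies between. On that basis compound 4 is expected to move upward by about a 1.6-fold higher number from compound 3 to compound 4 (0.20 log units; within the scatter), beyond the scatter but without reaching the limit with certainty. The estimate for compound 4 is 80000 nM, with a range from 35000 nM to 150000 nM.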

Compound 4, minimum cytotoxic concentration: 25000 nM
For compound 4 the middle estimate is 3.2-fold (0.51 log units) above the measured one; measured number below the stated range.
By their numbers in this assay, from the lowest: compounds 1, 4 and 3 (each within the scatter of the next, the first and the last beyond it). At a limit, above all of these: compound 2.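

In this assay, for the compounds shown here, the change from propyl to ethyl reads as a 2.0-fold lower number from compound 3 to compound 4 (0.30 log units; within the scatter), so hydrogen in place of methyl on a saturated chain carbon, two bonds along the chain from an aromatic carbon, gives no step that can be told from repeat scatter. This pair is the only direct read on chain length in the series, and at this place the ethyl and propyl chains cannot be separated on minimum cytotoxic concentration. Compound 4 has a measured number, and compound 2 alone stands at a limit: the limit of > 100000 nM in this assay, at which 1 of the 4 values shown sits.

The compounds shown leave open how a methyl or a pentyl chain at this place would read. Also open, going by these compounds, is whether an ethyl chain carrying a hydroxyl group or an amine would read differently from compound 4.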